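Urea Against Amide: Weighing a Chlorinated Urea

The compounds below may be only part of what the source reports. "The series", "measured", "known", "first", "only" and "open" are said of these compounds alone.

Measured so far in a functional assay on MDA-MB-468 cells (Homo sapiens) for inhibition, read by sulforhodamine B assay, with a stated time of 48 h; a lower number here means a stronger inhibitor of growth, a higher number a weaker inhibitor of growth:
Compound 1 `COc1cc(-c2nn(-c3cccc(NC(=O)Nc4cccc(C(F)(F)F)c4)c3)cc2-c2ccncc2)ccc1Cl` gives 2160 nM.
Compound 2 `COc1cc(-c2nn(-c3cccc(NC(=O)c4ccc(Cl)c(C(F)(F)F)c4)c3)cc2-c2ccncc2)ccc1Cl` gives > 32500 nM, which is a limit of the assay rather than a number.

Compound 2 thus stands at the weak end of what has been measured, since its value is only a limit (the limit of > 32500 nM in this assay, at which 1 of the 2 values shown sits), and compound 1 alone carries a real number. Among the compounds with values here, the single measured step, an at least 15-fold higher number from compound 1 to compound 2 (1.17 log units; beyond the scatter), is large. Compound 3 `COc1cc(-c2nn(-c3cccc(NC(=O)Nc4ccc(Cl)c(C(F)(F)F)c4)c3)cc2-c2ccncc2)ccc1Cl` differs from compound 2 in one place: (4-chloro-3-(trifluoromethyl)phenyl)amino in place of 4-chloro-3-(trifluoromethyl)phenyl on a carbonyl carbon. This puts back the amide-type nitrogen on the carbonyl carbon, so compound 3 has the same arrangement there as compound 1 while keeping the 4-chloro-3-(trifluoromethyl)phenyl group of compound 2. Because the step of an at least 15-fold higher number from compound 1 to compound 2 (1.17 log units; beyond the scatter) was large toward weaker growth inhibition when that nitrogen was removed and the chlorine added, reinstating the nitrogen is expected to move the number back toward compound 1, a large step of an at least 16-fold lower number from compound 2 to compound 3 (1.21 log units; beyond the scatter). Compound 3 is therefore estimated at 2000 nM, with a range from 700 nM to 6000 nM in this assay.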

Compound 3, concentration for total growth inhibition: 4420 nM
The estimate for compound 3 lay 2.2-fold (0.34 log units) below the measured number; the range from low to high includes it.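

With the chlorine held constant, this pair isolates the nitrogen on the carbonyl carbon, the change between an amide and a urea, and in this assay the step is large: an at least 7.3-fold lower number from compound 2 to compound 3 (0.86 log units; beyond the scatter). The chlorine on its own, in place of hydrogen on an aromatic carbon, has a much smaller effect on the ureas, a 2.0-fold higher number from compound 1 to compound 3 (0.31 log units; beyond the scatter), so the urea nitrogen, and not the chlorine, accounts for most of the loss seen in compound 2. Compound 2 has only a limit of the assay and not a number, so the true size of its steps remains unknown: the limit of > 32500 nM in this assay, at which 1 of the 3 values shown sits.

From the compounds shown here alone, how an amide carrying the 3-(trifluoromethyl)phenyl group without the chlorine would compare remains open. So does whether a fluoro or methyl group in place of the chloro would track with hydrogen or with chloro on the urea.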